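Swapping the methoxy for trifluoromethyl on the ester aryl ring

This account rests on a few compounds, and the source may have more. Where it says the series, first, only, none or still open, it means among the compounds named here.

Measured compounds:
compound 1 `COc1ccc(C(=O)Oc2cc3c(cc2C)[C@@H](C(C)C)CC=C3C)cc1`, 80.1%
compound 2 `COc1cccc(C(=O)Oc2cc3c(cc2C)[C@@H](C(C)C)CC=C3C)c1`, 11.9%
compound 3 `CC1=CC[C@H](C(C)C)c2cc(C)c(OC(=O)c3cccc(Cl)c3)cc21`, 40.4%

In a functional assay on MCF7 cells (Homo sapiens) for antiproliferative activity, read by sulforhodamine B assay, with a stated time of 48 h, tested at 50 uM (a higher number here means more inhibition at the concentration tested (going by the name of the read-out), a lower number less inhibition), compound 1 gives the highest number of the three; compound 3 sits a number 39.7 percentage points lower from compound 1 to compound 3 (beyond the scatter) and compound 2 sits a number 68.2 percentage points lower from compound 1 to compound 2 (beyond the scatter). Compound 4 `CC1=CC[C@H](C(C)C)c2cc(C)c(OC(=O)c3ccc(C(F)(F)F)cc3)cc21` differs from compound 1 by one change: trifluoromethyl in place of methoxy on an aromatic carbon. Within the data shown here, no measured step swaps the substituent at this position of the ring, so the bearing of the known steps is indirect. The closest is a number 28.5 percentage points higher from compound 2 to compound 3 (beyond the scatter), where a different group replaced methoxy and the number rose modestly, while both moves away from compound 1 gave large drops. For compound 4 a step of a number 25.1 percentage points lower from compound 1 to compound 4 (beyond the scatter) is expected. Compound 4 is therefore estimated at 55%, with a range from 20% to 85%.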

Compound 4, a percentage reported as inhibition, at one concentration (the size of the read-out at that concentration, not a potency): 40.4%
Compound 4: middle estimate off by 14.6 percentage points, on the high side; low and high end bracket the measured number.
By their numbers in this assay, from the lowest: compound 2; then compounds 3 and 4 (each within the scatter of the next); then compound 1.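

In this assay, putting trifluoromethyl in place of methoxy on the aromatic carbon para to a large group gives a number 39.7 percentage points lower from compound 1 to compound 4 (beyond the scatter). The earlier steps shown here from compound 1 all moved the substituent to another ring position, whereas this one keeps the position and changes only the group. It shows that the high number of compound 1 depends on the group itself, not just on having a substituent at this position. Nothing available explains this drop.

Going by these compounds, it remains open whether an amine, a hydroxyl or a longer ethoxy chain at this position would keep the number of compound 1.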